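A few compounds are considered here, and "the series" means these few. Any claim that something is new, unique, unknown or untested is made for them only; others in the source may bear on it.

Values in a functional assay on HBC4 cells (Homo sapiens) for inhibition, read by sulforhodamine B assay, with a stated time of 48 h; on this read-out lower numbers stand for stronger inhibition of growth and higher numbers for weaker inhibition of growth:
- compound 1 `CCCCCCCCCCCC[C@@H](O)[C@H]1CC[C@H]([C@H](O)CCCCCCCCCCNC(=O)c2ccnn2C)O1`: 100000 nM
- compound 2 `CCCCCCCCCCCC[C@@H](O)[C@H]1CC[C@H]([C@H](O)CCCCCCCCCCNCc2ccnn2C)O1`: 1820 nM

For the measured compounds named here, compound 1 holds the higher of the two numbers, and a 55-fold lower number from compound 1 to compound 2 (1.74 log units; beyond the scatter) is the only measured step. Compound 3 `CCCCCCCCCCCC[C@@H](O)[C@H]1CC[C@H]([C@H](O)CCCCCCCCCCOC(=O)c2ccnn2C)O1` has not yet been measured. Its change from compound 1 is ((1-methyl-1H-pyrazol-5-yl)carbonyl)oxy in place of ((1-methyl-1H-pyrazol-5-yl)carbonyl)amino on a saturated chain carbon, ten or more bonds along the chain from an oxygen on a saturated carbon and a saturated ring carbon.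

Going by the values given here, no measured step tests this exchange directly. Among the compounds with values here, the one available step replaced the carbonyl and kept the nitrogen, whereas compound 3 keeps the carbonyl and loses the amide hydrogen. That step, a 55-fold lower number from compound 1 to compound 2 (1.74 log units; beyond the scatter), therefore gives only a loose sense of scale. With compound 1 at 100000 nM, the expectation is a smaller move toward a lower number in this assay, with low confidence. The estimated change is a 5.0-fold lower number from compound 1 to compound 3 (0.70 log units; beyond the scatter). The estimated value for compound 3 is 20000 nM, with an expected range of 4000 nM to 100000 nM.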

Compound 3, concentration for 50% growth inhibition: 51300 nM
The estimate for compound 3 lay 2.6-fold (0.41 log units) below the measured number; low and high end bracket the measured number.
By their numbers in this assay, from the lowest: compound 2; then compounds 3 and 1 (each within the scatter of the next).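

In this assay, the exchange of ((1-methyl-1H-pyrazol-5-yl)carbonyl)amino for ((1-methyl-1H-pyrazol-5-yl)carbonyl)oxy gives a 1.9-fold lower number from compound 1 to compound 3 (0.29 log units; within the scatter) and so does not separate the two groups, even though the amide hydrogen is lost. By contrast, the ((1-methyl-1H-pyrazol-5-yl)methyl)amino and ((1-methyl-1H-pyrazol-5-yl)carbonyl)oxy groups are clearly separated, with a 28-fold higher number from compound 2 to compound 3 (1.45 log units; beyond the scatter) as the large step. Across these three compounds, the large difference follows the carbonyl rather than the amide hydrogen: the two that carry the carbonyl stay within the scatter of each other, and the one without it stands apart.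

A tertiary amine bearing a methyl group, or an ether to the same (1-methyl-1H-pyrazol-5-yl)methyl group, would show whether the amine nitrogen and its hydrogen matter once the carbonyl is gone. Nothing available bears on the reason for these differences.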